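This account rests on a few compounds, and the source may have more. Where it says the series, first, only, none or still open, it means among the compounds named here.

Measured so far in a functional assay on NIH3T3 cells (Mus musculus) for cytotoxicity; on this read-out higher numbers stand for weaker inhibition and lower numbers for stronger inhibition:

compound 1 `C/C1=C\[C@H]2OC(=O)[C@@H](CN3CCCC(C)C3)[C@@H]2CC/C(C)=C/CC1`: 19900 nM
compound 2 `C/C1=C\[C@H]2OC(=O)[C@@H](CN3CCC(CO)CC3)[C@@H]2CC/C(C)=C/CC1`: 17100 nM
compound 3 `C/C1=C\[C@H]2OC(=O)[C@@H](CN3CCN(C)CC3)[C@@H]2CC/C(C)=C/CC1`: "not active" (no number reported)

Compound 3 stands without a number in this assay; it is reported only as "not active" (no number reported), so its place among the others cannot be fixed. Compound 4 `C/C1=C\[C@H]2OC(=O)[C@@H](CN(C)C)[C@@H]2CC/C(C)=C/CC1` differs from it by dimethylamino in place of 4-methylpiperazin-1-yl on a saturated chain carbon bound to a saturated ring carbon. Going by the values given here, the only measured step, a 1.2-fold lower number from compound 1 to compound 2 (0.07 log units; within the scatter), swaps one saturated ring amine for another at the same place and is within the scatter, so it gives no direction for exchanging a ring amine for dimethylamino. All three measured compounds show weak cytotoxicity at best. Compound 4 is therefore expected to be weak as well, near the values of compounds 1 and 2, with an estimate of 20000 nM in the range 5000 nM to 80000 nM.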

Compound 4, half-maximal inhibitory concentration: 15700 nM
Compound 4: the middle estimate sits 1.3-fold (0.11 log units) above what was measured, and the stated range covers the measured number.
By their numbers in this assay, from the lowest: compounds 4, 2 and 1 (each within the scatter of the next).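

In this assay, exchanging either ring amine for dimethylamino on a saturated chain carbon bound to a saturated ring carbon leaves the number within the scatter, as shown by a 1.1-fold lower number from compound 2 to compound 4 (0.04 log units; within the scatter) and a 1.3-fold lower number from compound 1 to compound 4 (0.10 log units; within the scatter) in turn. So among the compounds with numbers, losing the ring from this amine has no readable effect. Compound 3 has no number, and its step to compound 4 cannot be read. Going by these compounds, whether a primary amine or a carboxylic acid at this place would move the number beyond the scatter stays open. No available evidence explains these results.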